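Shrinking one ring on a long-lived amide

This account rests on a few compounds, and the source may have more. Where it says the series, first, only, none or still open, it means among the compounds named here.

In an ADME assay on microsomes from liver (Mus musculus, strain CD-1) for metabolic stability, read by LC-MS, tested at 2 uM (a higher number here means that the compound lasts longer, a lower number that the compound disappears faster), compound 1 (`Cn1ccc2ccc(-c3cc(Nc4ccccc4S(=O)(=O)Nc4cncnc4)cc4nccnc34)cc21`) gives 0.683 h as its half-life, and compound 2 (`CN(Cc1cncnc1)S(=O)(=O)c1ccccc1Nc1cc(-c2ccc3ccn(C)c3c2)c2nccnc2c1`) gives 0.2 h as its half-life. Those two compounds differ in one place, on a sulfonyl sulfur, where methyl((pyrimidin-5-yl)methyl)amino stands in place of (pyrimidin-5-yl)amino. The result is a 3.4-fold lower number from compound 1 to compound 2 (0.53 log units; beyond the scatter) in this one measured step.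

Compound 3 (`CN1CCC(NC(=O)c2ccncc2Nc2cc(-c3ccc4ccn(C)c4c3)c3nccnc3c2)CC1`) stands at > 1 h in this assay and this reading is a limit of the assay, not a number.

Compound 4 (`CN1CC(NC(=O)c2ccncc2Nc2cc(-c3ccc4ccn(C)c4c3)c3nccnc3c2)C1`) differs from compound 3 in a single group, with 1-methylazetidin-3-yl in place of 1-methylpiperidin-4-yl on an amide-type nitrogen. Among the compounds with values here, no measured step touches this group. Within the data shown here, the step on the sulfonyl sulfur lies elsewhere in the molecule, so it shows only that one change can move the half-life noticeably, and it gives no direction for this swap. With no direct evidence, no step beyond the usual scatter is expected, and the estimated move is a step that the limit leaves unreadable from compound 3 to compound 4 at most modestly. For compound 4 the estimate is 1.2 h with an expected range from 0.5 h to 3 h in this assay. A limit of the assay rather than a number may well be the outcome.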

Compound 4, half-life: > 1 h
Compound 4 gave a limit, no number (the forecaster's own chance of this, stated with the estimate: 55%); the middle value does not contradict the limit.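

Within the data shown here, compound 3 and compound 4 both end at a limit of the assay rather than a number, so the swap from 1-methylpiperidin-4-yl to 1-methylazetidin-3-yl gives no step that can be read: the limit of > 1 h in this assay, at which 2 of the 4 values shown sit. The compounds shown leave open how far past that limit each half-life lies, and whether the four-membered ring changes it at all.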